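This account rests on a few compounds, and the source may have more. Where it says the series, first, only, none or still open, it means among the compounds named here.

Measured so far in a functional assay on OVCAR-3 cells (Homo sapiens) for cytotoxicity, read by sulforhodamine B assay, with a stated time of 48 h, tested at 10 uM; a lower number here means a stronger effect, a higher number a weaker effect of the compound at the concentration tested:
Compound 1 `COc1cc(-c2cc(/C=C/C(=O)c3ccc(N)cc3)[nH]n2)cc(OC)c1OC`: -71%
Compound 2 `COc1cc(-c2cc(/C=C/C(=O)c3ccc(Cl)c(Cl)c3)[nH]n2)cc(OC)c1OC`: 40%
Compound 3 `COc1ccc(C(=O)/C=C/c2cc(-c3cc(OC)c(OC)c(OC)c3)n[nH]2)cc1`: -72%

Compound 3 has the lowest number of the three in this assay; compound 1 sits within the scatter of it, while compound 2 lies far higher. Compound 4 `COc1cc(-c2cc(/C=C/C(=O)c3ccc(F)c(F)c3)[nH]n2)cc(OC)c1OC` differs from compound 3 only in one place: 3,4-difluorophenyl in place of 4-methoxyphenyl on a carbonyl carbon. Among the compounds with values here, two measured steps bear on this, as both exchange the aryl group on the same carbonyl carbon: a number 111 percentage points higher from compound 1 to compound 2 (beyond the scatter) and a number 112 percentage points lower from compound 2 to compound 3 (beyond the scatter). Both show that a 3,4-dichlorophenyl ring on that carbon goes with a much higher number than a 4-aminophenyl or 4-methoxyphenyl ring. A 3,4-difluorophenyl ring is expected to behave in the same direction, so a large rise, a number 92 percentage points higher from compound 3 to compound 4 (beyond the scatter), is expected for compound 4. Compound 4 is therefore estimated at 20% in this assay, with a range from -40% to 60%.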

Compound 4, a percentage reported as activity, at one concentration (the size of the read-out at that concentration, not a potency): -24%
Estimate against measurement, compound 4: 44 percentage points above; the measured number falls inside the stated range.
By their numbers in this assay, from the lowest: compounds 3 and 1 (each within the scatter of the next); then compound 4; then compound 2.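

With the 3,4-difluorophenyl ring on the carbonyl carbon, compound 4 takes a middle place, showing a number 48 percentage points higher from compound 3 to compound 4 (beyond the scatter) and a number 47 percentage points higher from compound 1 to compound 4 (beyond the scatter) but also a number 64 percentage points lower from compound 2 to compound 4 (beyond the scatter). This position therefore gives more than two levels among the compounds shown, and exchanging the 3,4-dichlorophenyl ring for the 3,4-difluorophenyl ring alone brings a large step. Nothing available accounts for this order.

On these data alone, what a 4-fluorophenyl or 4-hydroxyphenyl ring would give on this carbonyl carbon remains open. Also open, as far as these compounds go, is whether the order of these rings would hold with another group, such as a 4-methoxyphenyl ring, in place of the trimethoxyphenyl ring of the shared core.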